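Adding Chloro to the Phenyl Ring of Compound 3

A few compounds are considered here, and "the series" means these few. Any claim that something is new, unique, unknown or untested is made for them only; others in the source may bear on it.

Measured in an assay on CHO cells for displacement of a labelled ligand from prostaglandin D2 receptor 2 (Homo sapiens), read by scintillation counting; a higher number here means a weaker inhibitor, a lower number a stronger inhibitor:
compound 1, `O=C(O)COc1ccc(Cl)cc1C#Cc1ccncc1`, gives 601 nM
compound 2, `O=C(O)COc1ccc(Cl)cc1C#Cc1ccccc1Cl`, gives 28 nM
compound 3, `O=C(O)COc1ccc(Cl)cc1C#Cc1ccccc1`, gives 108 nM

Compound 3 holds the second highest of the three numbers in this assay. Its nearest neighbour is compound 2, as the step of a 3.9-fold higher number from compound 2 to compound 3 (0.59 log units; beyond the scatter) shows; its furthest is compound 1, as the step of a 5.6-fold lower number from compound 1 to compound 3 (0.75 log units; beyond the scatter) shows. Compound 4, `O=C(O)COc1ccc(Cl)cc1C#Cc1ccc(Cl)cc1`, has not yet been measured; it differs from compound 3 by chloro in place of hydrogen on an aromatic carbon.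

Going by the values given here, no measured step adds a chloro at this place on the phenyl ring. The step that bears most closely on it is the one in which a chloro on an aromatic carbon of that ring is removed, a 3.9-fold higher number from compound 2 to compound 3 (0.59 log units; beyond the scatter), a modest rise. The pair of steps a 21-fold lower number from compound 1 to compound 2 (1.33 log units; beyond the scatter) and a 5.6-fold lower number from compound 1 to compound 3 (0.75 log units; beyond the scatter) point the same way: the chlorophenyl compound sits well below the plain phenyl compound. Whether a chloro at the new place acts like the one in compound 2 is not shown by these three compounds.

On that basis compound 4 is expected to give a modestly lower number than compound 3, a step of about a 2.0-fold lower number from compound 3 to compound 4 (0.29 log units; within the scatter). Compound 4 is therefore estimated at 55 nM, with a range from 18 nM to 170 nM.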

Compound 4, inhibition constant: 60 nM
Compound 4: middle estimate off by 1.1-fold (0.04 log units), on the low side; the range from low to high includes it.
By their numbers in this assay, from the lowest: compound 2; then compounds 4 and 3 (each within the scatter of the next); then compound 1.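

In this assay, going by these compounds alone, the chloro para to a large group brings a 1.8-fold lower number from compound 3 to compound 4 (0.26 log units; within the scatter), so at this place on the phenyl ring the added chloro cannot be told apart from hydrogen, which the earlier compounds, with their only chloro on that ring in the 2-chlorophenyl group of compound 2, could not show. Where the chloro stands on the ring does count, however: the change from 2-chlorophenyl to 4-chlorophenyl brings a 2.1-fold higher number from compound 2 to compound 4 (0.33 log units; beyond the scatter), a modest step beyond the scatter that leaves compound 2 with the lower number of the two. The 4-chlorophenyl group also stays well clear of pyridin-4-yl, as a 10-fold lower number from compound 1 to compound 4 (1.00 log units; beyond the scatter) shows, and nothing measured here explains any of these differences.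

Still open, from the compounds shown here alone, is whether a 2,4-dichlorophenyl ring, filling both places with chloro, would go beyond compound 2 in this assay. Also open, going by these compounds, is whether a different group para to the large group, such as methoxy, fluoro or an amine, would separate from hydrogen where chloro does not.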